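Swapping nitro for fluoro on the benzyl arm of compound 3

This account rests on a few compounds, and the source may have more. Where it says the series, first, only, none or still open, it means among the compounds named here.

Compound 1 `CC(C)(C)OC(=O)CNCc1ccc(Cl)cc1`: "not determined" (no result reported)
Compound 2 `CC(C)(C)OC(=O)CN(Cc1ccncc1)Cc1ccc(Cl)cc1`: "not determined" (no result reported)
Compound 3 `CC(C)(C)OC(=O)CN(Cc1ccc([N+](=O)[O-])cc1)Cc1ccc([N+](=O)[O-])s1`: 2500 nM

Of the three compounds, only compound 3 carries a number in a functional assay on HEK293 cells for agonist activity at nuclear receptor subfamily 1 group D member 1 (Homo sapiens), read by a luciferase reporter, with a stated time of 24 h; a lower number here means that less compound is needed, a higher number that more compound is needed for the effect; compound 3 gives 2500 nM there, and no result is reported for compound 1 or compound 2. Compound 4 `CC(C)(C)OC(=O)CN(Cc1ccc(F)cc1)Cc1ccc([N+](=O)[O-])s1` differs from compound 3 by one change: fluoro in place of nitro on an aromatic carbon. Going by the values given here, no measured pair illustrates this exchange, so the size of the step rests on the single anchor. The remaining parts of compound 4 are unchanged, and the expected step from compound 3 to compound 4 is a 1.3-fold lower number from compound 3 to compound 4 (0.10 log units; within the scatter), judged as none beyond the scatter. Compound 4 is therefore expected to give about 2000 nM in this assay, within a range from 700 nM to 6000 nM.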

Compound 4, half-maximal effective concentration: 2000 nM
Compound 4: the middle estimate sits on the measured number at the digits printed; low and high end bracket the measured number.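

In this assay, the 4-nitrophenyl to 4-fluorophenyl exchange gives a 1.3-fold lower number from compound 3 to compound 4 (0.10 log units; within the scatter). Going by these compounds alone, at this position, therefore, the read-out does not depend on the nitro group: a single fluoro atom in its place serves equally well, and this is the first measured step at this position. No measurement shown offers an explanation for this tolerance. The compounds shown leave open whether an amine or a carboxylic acid at the same aromatic carbon would also leave the number within the scatter. They also leave open what replacing the nitro group on the other arm would do.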